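Swapping the amide-nitrogen group of compound 3

The source may hold more compounds than are shown below. What is called first, only, known or untested is meant among the compounds shown, and "the series" means these compounds.

Measured in a functional assay on A549 cells (Homo sapiens) for cytotoxicity, read by MTT assay, with a stated time of 72 h; a higher number here means a weaker inhibitor, a lower number a stronger inhibitor:
- compound 1 `O=C(CN1CCN(c2nnc(Cc3ccncc3)c3ccccc23)CC1)Nc1ccc(Br)cc1`: 2710 nM
- compound 2 `Cc1ccc(F)cc1NC(=O)CN1CCN(c2nnc(Cc3ccccc3)c3ccccc23)CC1`: "not active" (no number reported)
- compound 3 `Cc1ccc(F)cc1NC(=O)CN1CCN(c2nnc(Cc3ccncc3)c3ccccc23)CC1`: 38900 nM

Of the two numbers available, compound 3 has the higher, 38900 nM, which makes it the weaker of that pair. Compound 4 `Cc1cccc(Cl)c1NC(=O)CN1CCN(c2nnc(Cc3ccncc3)c3ccccc23)CC1` differs from it in a single place: 2-chloro-6-methylphenyl in place of 5-fluoro-2-methylphenyl on an amide-type nitrogen. Among the compounds with values here, only one measured step bears on this place, a 14-fold higher number from compound 1 to compound 3 (1.16 log units; beyond the scatter). That step involves different groups, so it shows that this position can matter but gives no firm direction. With compound 3 already at 38900 nM, a moderate move towards a lower number seems more likely than a further rise. The expected change is a 2.6-fold lower number from compound 3 to compound 4 (0.41 log units; beyond the scatter). For compound 4 the estimated value is 15000 nM, with an expected range from 3000 nM to 60000 nM.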

Compound 4, half-maximal inhibitory concentration: 7190 nM
Beside the measured number, compound 4's estimate is 2.1-fold (0.32 log units) above it, and the stated range covers the measured number.
By their numbers in this assay, from the lowest: compound 1; then compound 4; then compound 3.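

In this assay the change to 2-chloro-6-methylphenyl gives a 5.4-fold lower number from compound 3 to compound 4 (0.73 log units; beyond the scatter) and so shows that two groups with the same heavy-atom count, each carrying a methyl and one halogen, can still differ clearly at this amide-type nitrogen. The 4-bromophenyl group of compound 1 keeps the lowest number, with a 2.7-fold higher number from compound 1 to compound 4 (0.42 log units; beyond the scatter) as the remaining gap. No measured evidence accounts for these differences.

Going by these compounds, it remains open whether an amine or a carboxylic acid on this phenyl ring would lower the number further or raise it.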